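The compounds below may be only part of what the source reports. "The series", "measured", "known", "first", "only" and "open" are said of these compounds alone.

In an ADME assay on microsomes from liver (Homo sapiens) for metabolic stability, read by LC-MS, with NADPH named in the record, with a stated time of 60 min, tested at 1 uM, in the absence of a further agent (on this read-out lower numbers stand for a less stable compound and higher numbers for a more stable compound), compound 3 `COc1ccc(-c2c(C)nc3c(N4CC[C@@H](NC(=O)c5ccccc5)C4)cc(C)nn23)cc1OC` gives only a limit, > 95%. Compound 1 `COc1ccc(-c2c(C)nc3c(N4CC[C@@H](NC(C)=O)C4)cc(C)nn23)cc1OC` also gives only a limit, > 95%. Compound 2 `CC(=O)N[C@@H]1CCN(c2cc(C)nn3c(-c4ccc(OC(F)(F)F)cc4)c(C)nc23)C1` likewise gives only a limit, > 95%. Compound 4 `COc1ccc(-c2c(C)nc3c(N4CC[C@@H](NC(=O)NC(C)C)C4)cc(C)nn23)cc1OC` differs from compound 3 as follows: isopropylamino in place of phenyl on a carbonyl carbon. In short, isopropylamino stands in place of phenyl on a carbonyl carbon. Among the measured compounds shown here, the one measured step at this carbonyl carbon is a step that the two limits leave unreadable from compound 1 to compound 3, so its size offers no number to carry over. What remains is the limit of > 95% in this assay, at which 3 of the 3 values shown sit, which gives no sign of a drop on this series. The expected step of a number at least 2 percentage points lower from compound 3 to compound 4 (that floor lies within the scatter) is therefore none beyond the scatter, with no direction foreseen. For compound 4 the estimated value is 93%, with an expected range from 82% to 100%.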

Compound 4, percent of the compound remaining: > 95%
Compound 4 ended at the assay's limit (the forecaster's own chance of this, stated with the estimate: 60%); middle value at least 2 percentage points from the limit.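

Compound 4, like compound 1 and compound 3, gives only a limit in this assay, so neither step to compound 4 can be read. The compounds shown leave open whether methyl, phenyl and isopropylamino on this carbonyl carbon differ at all in the percent of compound remaining: the limit of > 95% in this assay, at which 4 of the 4 values shown sit.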